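From 2-methylphenyl to 4-methylphenyl: compound 2 to compound 3

A few compounds are considered here, and "the series" means these few. Any claim that something is new, unique, unknown or untested is made for them only; others in the source may bear on it.

In a functional assay on K562 cells (Homo sapiens) for inhibition, read by trypan blue exclusion, with a stated time of 24 h, tested at 10 uM (a lower number here means less inhibition of growth, a higher number more inhibition of growth at the concentration tested), compound 1 `Cc1ccc(OCC(=O)Nc2ccccc2C(N)=O)cc1` gives < 10% as a limit and not a number. Within the data shown here, compound 2 `COc1ccc(NC(=O)COc2ccccc2C)c(C(N)=O)c1` gives 40.1% in this assay and holds the only actual number so far. Compound 3 `COc1ccc(NC(=O)COc2ccc(C)cc2)c(C(N)=O)c1` has the same atoms joined differently, with 4-methylphenyl in place of 2-methylphenyl on an oxygen on a saturated carbon. Among the measured compounds shown here, no measured step bears on this change, so only a small fall in this assay is expected, not clearly beyond the scatter (a number 8.1 percentage points lower from compound 2 to compound 3 (within the scatter)). For compound 3 the estimated value is 32% (range 12% to 52%) until a measurement is available.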

Compound 3, percent growth inhibition at one concentration: 48.1%
Beside the measured number, compound 3's estimate is 16.1 percentage points below it, and the stated range covers the measured number.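

In this assay, 4-methylphenyl in place of 2-methylphenyl on an oxygen on a saturated carbon gives a number 8 percentage points higher from compound 2 to compound 3 (within the scatter), so this change does not separate the two compounds. Methoxy in place of hydrogen on an aromatic carbon gives a number at least 38.1 percentage points higher from compound 1 to compound 3 (beyond the scatter), the only step here beyond the scatter. Compound 1 stands as a limit and not a number, so that step has no exact size: the limit of < 10% in this assay, at which 1 of the 3 values shown sits.

The compounds shown leave open how a carboxylic acid or a longer chain in place of 4-methylphenyl would read. They also leave open whether an amine in place of the methoxy would match it.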